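From 3-fluorophenyl to 3-methylphenyl on the shared core

The source may hold more compounds than are shown below. What is called first, only, known or untested is meant among the compounds shown, and "the series" means these compounds.

In an ADME assay on HUVEC cells (Homo sapiens) for cytotoxicity, read by MTT assay, with a stated time of 24 h (on this read-out lower numbers stand for higher toxicity in this test and higher numbers for lower toxicity in this test), compound 3 (`Fc1cccc(/C=C/c2nnc(-c3ccc4c(c3)OCCO4)o2)c1`) gives 295000 nM and stands within the scatter of compound 1 (`Brc1cccc(/C=C/c2nnc(-c3ccc4c(c3)OCCO4)o2)c1`) at 322000 nM and of compound 2 (`O=[N+]([O-])c1ccccc1/C=C/c1nnc(-c2ccc3c(c2)OCCO3)o1`) at 323000 nM on the same read-out. Compound 4 (`Cc1cccc(/C=C/c2nnc(-c3ccc4c(c3)OCCO4)o2)c1`) has methyl in place of fluoro on an aromatic carbon, with methyl in place of fluoro on an aromatic carbon as the counted difference. Among the compounds with values here, the only measured step exchanging one such group is fluoro in place of bromo, a 1.1-fold lower number from compound 1 to compound 3 (0.04 log units; within the scatter) and within the scatter. No step beyond the scatter is therefore expected in this assay for this change. An estimated 1.1-fold higher number from compound 3 to compound 4 (0.02 log units; within the scatter) is expected here. For compound 4 the estimated value is 310000 nM with an expected range from 190000 nM to 500000 nM in this series.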

Compound 4, half-maximal cytotoxic concentration: 201000 nM
Compound 4: middle estimate off by 1.5-fold (0.19 log units), on the high side; the measured number falls inside the stated range.
By their numbers in this assay, from the lowest: compounds 4, 3, 1 and 2 (each within the scatter of the next).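

In this assay the position meta to a large group now carries methyl as well as halogens: methyl in place of fluoro gives a 1.5-fold lower number from compound 3 to compound 4 (0.17 log units; within the scatter) and methyl in place of bromo gives a 1.6-fold lower number from compound 1 to compound 4 (0.20 log units; within the scatter). Bromo, fluoro and methyl at this position therefore all stay within the scatter of one another in this series. No evidence on the reason for these small steps is at hand.

Going by these compounds, whether an amine, a carboxylic acid or a longer chain at this position would stay within the same scatter remains open.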